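Cyclopropylmethyl versus 4-fluorobenzyl amines on two related cores

A few compounds are considered here, and "the series" means these few. Any claim that something is new, unique, unknown or untested is made for them only; others in the source may bear on it.

Compound 1 `Cn1cc(-c2cnc3ccc(NCC4CC4)nc3c2)cn1` and compound 2 `Cn1cc(-c2cnc3ccc(NCc4ccc(F)cc4)nc3c2)cn1` share one core; compound 3 `Cn1cc(-c2cnc3ccnc(NCC4CC4)c3c2)cn1` and compound 4 `Cn1cc(-c2cnc3ccnc(NCc4ccc(F)cc4)c3c2)cn1` share another. The difference between the two cores is not broken down here. In a functional assay on A549 cells (Homo sapiens) for antiproliferative activity, read by MTT assay, with a stated time of 48 h (a higher number here means a weaker inhibitor, a lower number a stronger inhibitor), compound 1 gives only a limit, > 50000 nM. In this assay compound 2 likewise gives only a limit, > 50000 nM. The step that the two limits leave unreadable from compound 1 to compound 2, the change (4-fluorophenyl in place of cyclopropyl on a saturated chain carbon bound to a nitrogen on an aromatic ring), therefore cannot be sized; both values sit at the limit of > 50000 nM in this assay, at which 2 of the 3 values shown sit. In this assay, for the measured compounds named here, compound 3 gives 8900 nM, the only number in the set. Compound 4 carries the same change on the core of compound 3: 4-fluorophenyl in place of cyclopropyl on a saturated chain carbon bound to a nitrogen on an aromatic ring. Since the measured step from compound 1 to compound 2 is not readable, no size for this change can be taken from the series. The estimate for compound 4 therefore rests on compound 3 alone at 8900 nM, with the step of a 1.3-fold higher number from compound 3 to compound 4 (0.13 log units; within the scatter) expected to stay near the scatter. Compound 4 is expected in this assay at 12000 nM, between 3000 nM and 50000 nM.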

Compound 4, half-maximal inhibitory concentration: 5200 nM
For compound 4 the middle estimate is 2.3-fold (0.36 log units) above the measured one; the range from low to high includes it.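

In this assay, the change from cyclopropylmethyl to 4-fluorobenzyl on the core of compound 3 gives a 1.7-fold lower number from compound 3 to compound 4 (0.23 log units; within the scatter), so on this core the swap of the smaller carbon ring for the larger aromatic one has no effect that can be told from scatter. As far as these compounds go, on the core of compound 1 the same change cannot be read, since compound 1 and compound 2 each give only a limit: the limit of > 50000 nM in this assay, at which 2 of the 4 values shown sit. Carrying the change from one core to the other therefore remains untested, as a single readable step offers no second size to compare it with and shows neither agreement nor disagreement between the cores.

The compounds shown leave open whether any group at this place would move the number beyond the scatter on the core of compound 3. Candidates are phenyl without the fluorine, a longer chain such as cyclopropylethyl, or a chain ending in a piperidine or a carboxylic acid.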